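Swapping the ring on compound 1

The compounds below may be only part of what the source reports. "The series", "measured", "known", "first", "only" and "open" are said of these compounds alone.

Values in a physicochemical assay for solubility, measured as kinetic solubility; on this read-out lower numbers stand for lower solubility and higher numbers for higher solubility:
- Compound 1 `O=C(Nc1ccnnc1)c1cc(N2CCCC2)ccc1OCc1ccccc1`: 35000 nM
- Compound 2 `O=C(Nc1cccnc1)c1cc(C(F)(F)F)ccc1OCc1ccccc1`: < 1000 nM, a limit
- Compound 3 `N#Cc1cccc(NC(=O)c2cc(C(F)(F)F)ccc2OCc2ccc(F)cc2)c1`: < 1000 nM, a limit

Compound 1 is the only one of the three with a true number, and it stands well clear of the limit of < 1000 nM in this assay, at which 2 of the 3 values shown sit. Compound 4 `N#CC1CCN(c2ccc(OCc3ccccc3)c(C(=O)Nc3ccnnc3)c2)CC1` keeps the core of compound 1 but carries 4-cyanopiperidin-1-yl in place of pyrrolidin-1-yl on an aromatic carbon. Going by the values given here, no measured pair shows this exact change, so the expectation is only a cautious one, a moderate fall in this assay. The estimated step is a 2.3-fold lower number from compound 1 to compound 4 (0.37 log units; beyond the scatter). For compound 4 the expected value is 15000 nM, with an estimated range of 4000 nM to 40000 nM.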

Compound 4, solubility: < 1000 nM
Compound 4: only a limit was reported; the forecaster's own chance of this, stated with the estimate: 10%; at least 15-fold (1.17 log units) between middle value and limit.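

At the position para to a benzyloxy group, 4-cyanopiperidin-1-yl in place of pyrrolidin-1-yl gives an at least 35-fold lower number from compound 1 to compound 4 (1.54 log units; beyond the scatter) in this assay, so this one place on the shared core can move the read-out strongly. The value of compound 4 is only a limit, so the full size of this step stays unknown: the limit of < 1000 nM in this assay, at which 3 of the 4 values shown sit.

The compounds shown do not separate the six-membered ring from the nitrile, since compound 4 brings in both at once. Going by these compounds, how piperidin-1-yl without the nitrile, or morpholin-4-yl, would read at this position remains open.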